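A few compounds are considered here, and "the series" means these few. Any claim that something is new, unique, unknown or untested is made for them only; others in the source may bear on it.

Working notes on the triazole series

Compound 1 `COc1ccccc1-n1cc(COc2c(/C=C\C(=O)O)ccc(OC)c2CC=C(C)C)nn1` is measured in a functional assay on A-431 cells (Homo sapiens) for cytotoxicity, read by MTT assay, with a stated time of 24 h (a higher number here means a weaker inhibitor, a lower number a stronger inhibitor), where compound 1 gives 32600 nM. Within the three numbers so far, compound 1 stands level with compound 3 `COc1ccc(/C=C\C(=O)O)c(OCc2cn(-c3cccnc3Cl)nn2)c1CC=C(C)C`, for which this assay gives 32600 nM, the two together at the top; the step of no change at the digits printed from compound 1 to compound 3 (within the scatter) is no change at the digits shown. Compound 2 `COc1ccc(/C=C\C(=O)O)c(OCc2cn(-c3ccc(CO)cc3)nn2)c1CC=C(C)C` gives 16400 nM in this assay, and the step of a 2.0-fold lower number from compound 1 to compound 2 (0.30 log units; within the scatter) is likewise within the scatter.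

The next compound, compound 4 `COc1ccc(/C=C\C(=O)O)c(OCc2cn(-c3ccc(C#N)cc3)nn2)c1CC=C(C)C`, differs from compound 1 at a single place: 4-cyanophenyl in place of 2-methoxyphenyl on an aromatic nitrogen. The two measured steps that bear on it are the other swaps of the group on the same aromatic nitrogen, a 2.0-fold lower number from compound 1 to compound 2 (0.30 log units; within the scatter) and no change at the digits printed from compound 1 to compound 3 (within the scatter), both within the scatter. Neither gives any reason to expect that 4-cyanophenyl in place of 2-methoxyphenyl will move the number beyond the scatter in either direction; the shared core is otherwise untouched.

Compound 4 is therefore expected to give roughly 30000 nM in this assay, with a range from 12000 nM to 70000 nM. That estimate means a step of a 1.1-fold lower number from compound 1 to compound 4 (0.04 log units; within the scatter), that is, no change beyond the usual scatter.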

Compound 4, half-maximal inhibitory concentration: 23000 nM
For compound 4 the middle estimate is 1.3-fold (0.12 log units) above the measured one; the range from low to high includes it.
By their numbers in this assay, from the lowest: compounds 2, 4, 1 and 3 (each within the scatter of the next).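

In this assay the 4-cyanophenyl group on the aromatic nitrogen stays within the scatter of all three earlier groups, with the steps of a 1.4-fold lower number from compound 1 to compound 4 (0.15 log units; within the scatter) and a 1.4-fold lower number from compound 3 to compound 4 (0.15 log units; within the scatter) both read against groups that differ from it in more than one feature of the aromatic ring. The closest comparison is the step of a 1.4-fold higher number from compound 2 to compound 4 (0.15 log units; within the scatter), which isolates cyano in place of hydroxymethyl on an aromatic carbon and adds a group with a triple bond to the set, and this change also stays within the scatter. Across compounds 1 to 4, every step at this position lies within the scatter, so no group among these four can be ranked above another, and no information is available to explain the values at this position.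

Going by these compounds, whether an amine or a carboxylic acid in place of the cyano group, or a saturated alkyl chain in place of the aromatic ring on the nitrogen, would move the number beyond the scatter remains open. The rest of the shared core is the same in all four compounds, so these compounds leave open what its other parts contribute to the number.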